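Swapping 2-bromophenyl for 4-fluorophenyl in the series

The source may hold more compounds than are shown below. What is called first, only, known or untested is meant among the compounds shown, and "the series" means these compounds.

Going by the values given here, in a functional assay on MCF7 cells (Homo sapiens) for antiproliferative activity, read by MTT assay, with a stated time of 48 h (on this read-out higher numbers stand for weaker inhibition and lower numbers for stronger inhibition), compound 3 (`CCOC(=O)/C(=C/c1ccccc1)CN1C(=O)[C@@H](OC)[C@H]1c1ccccc1Br`) gives 5790 nM, the lowest of the three numbers so far. Compound 1 (`CCOC(=O)/C(=C/c1ccccc1)CN1C(=O)[C@@H](OC)[C@H]1c1ccc(Cl)cc1`) gives 12700 nM, and compound 2 (`COC(=O)/C(=C/c1ccccc1)CN1C(=O)[C@@H](OC)[C@H]1c1ccc(F)cc1`) gives 15600 nM. Compound 4 (`CCOC(=O)/C(=C/c1ccccc1)CN1C(=O)[C@@H](OC)[C@H]1c1ccc(F)cc1`) is unmeasured. It carries 4-fluorophenyl in place of the 2-bromophenyl of compound 3 on a saturated ring carbon: 4-fluorophenyl in place of 2-bromophenyl on a saturated ring carbon. Among the compounds with values here, the one measured step bearing on this is a 2.2-fold lower number from compound 1 to compound 3 (0.34 log units; beyond the scatter), modest and beyond the scatter, where 2-bromophenyl replaced 4-chlorophenyl. Compound 2 also bears 4-fluorophenyl and stands at 15600 nM. A step of similar size in the reverse direction, toward a higher number, is therefore expected in this assay: a 2.2-fold higher number from compound 3 to compound 4 (0.35 log units; beyond the scatter). Compound 4 is estimated at 13000 nM, with an expected range of 7000 nM to 24000 nM.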

Compound 4, half-maximal inhibitory concentration: 18800 nM
For compound 4 the middle estimate is 1.4-fold (0.16 log units) below the measured one, and the stated range covers the measured number.
By their numbers in this assay, from the lowest: compound 3; then compounds 1, 2 and 4 (each within the scatter of the next).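

In this assay, the aryl change on the saturated ring carbon gives a 3.2-fold higher number from compound 3 to compound 4 (0.51 log units; beyond the scatter), so 2-bromophenyl stands apart from 4-fluorophenyl as well as from 4-chlorophenyl. Fluoro in place of chloro gives a 1.5-fold higher number from compound 1 to compound 4 (0.17 log units; within the scatter) and methyl in place of hydrogen on the saturated chain carbon gives a 1.2-fold higher number from compound 2 to compound 4 (0.08 log units; within the scatter), both within the scatter, so neither change separates these compounds. Nothing measured here explains the separation of compound 3.

The compounds shown do not separate the identity of the halogen from where it sits on the phenyl ring. Also open, on these data alone, is whether an aryl group carrying an amine or a carboxylic acid would read nearer compound 3 or compound 4.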